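The compounds below may be only part of what the source reports. "The series", "measured", "known", "first", "only" and "open" are said of these compounds alone.

In a functional assay on HCT-116 cells (Homo sapiens) for cytotoxicity, read by scintillation counting and thymidine incorporation, with a stated time of 72 h (a lower number here means a stronger inhibitor, a higher number a weaker inhibitor), compound 2 `COc1cc(OC)cc(C(=CC#N)c2ccc(OC)c(OC)c2)c1` gives 18 nM, the higher of the two actual numbers in the series, and compound 3 `COc1cc(OC)cc(C(=CC#N)c2ccc(OC)c(O)c2)c1` gives 2.5 nM. That gap is a 7.2-fold lower number from compound 2 to compound 3 (0.86 log units; beyond the scatter). Compound 1 `COc1cc(OC)cc(C(=CC(N)=O)c2ccc(OC)c(OC)c2)c1` reports only a limit, > 10000 nM. The nitrile exchange is an at least 550-fold lower number from compound 1 to compound 2 (2.74 log units; beyond the scatter).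

Compound 4 `COc1cc(OC)cc(/C(=C\C#N)c2ccc(OC)c(OC)c2)c1` has the same atoms and bonds as compound 2: the two compounds have the same atoms and bonds; at least one stereo element is drawn with a configuration in one of them and without one in the other: 1 of 1 stereo elements differ; a double bond is drawn without a configuration in compound 2 and Z in compound 4. In words, a double bond is drawn without a configuration in compound 2 and Z in compound 4. Neither measured step touches this configuration. Among the measured compounds shown here, both an at least 550-fold lower number from compound 1 to compound 2 (2.74 log units; beyond the scatter) and a 7.2-fold lower number from compound 2 to compound 3 (0.86 log units; beyond the scatter) show only that single changes can move this assay well beyond the scatter. For the measured compounds named here, no measured pair isolates the configuration, so the direction stays open, and the range is kept wider on the weak side.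

The estimated step is a 1.2-fold lower number from compound 2 to compound 4 (0.08 log units; within the scatter), with no shift beyond the scatter expected. For compound 4 the expected value is 15 nM, with an estimated range of 4 nM to 150 nM.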

Compound 4, half-maximal inhibitory concentration: 11 nM
Beside the measured number, compound 4's estimate is 1.4-fold (0.13 log units) above it; measured number inside the range.
By their numbers in this assay, from the lowest: compound 3; then compounds 4 and 2 (each within the scatter of the next). At a limit, above all of these: compound 1.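

In this assay, the pair with the defined Z double bond gives a 1.6-fold lower number from compound 2 to compound 4 (0.21 log units; within the scatter). This is the only pair shown that concerns the double bond itself rather than a group exchange, and unlike the steps at the nitrile and at the ring oxygen, it stays within the scatter. The result cannot be read as a clean comparison of two geometries because the double bond has a drawn configuration in only one of the two compounds: the fact that one of compounds 2 and 4 is drawn with a defined configuration and the other without, at the place where they differ

As far as these compounds go, how the E double bond would read in this assay remains open, as does whether the hydrogen in place of methyl on the ring oxygen would carry over to the Z series. Also open, from the compounds shown here alone, is how a carboxylic acid or an amine in place of the nitrile would read on the Z double bond.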